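Replacing the aryl amide of compound 3

The source may hold more compounds than are shown below. What is called first, only, known or untested is meant among the compounds shown, and "the series" means these compounds.

compound 1 `CCn1c(C(=O)NCCCN(C)C)ccc1C(CC)(CC)c1ccc(OCCC(O)(CC)CC)c(C)c1` gives 2150 nM
compound 2 `CCn1c(C(=O)NCC#N)ccc1C(CC)(CC)c1ccc(OCCC(O)(CC)CC)c(C)c1` gives 17800 nM
compound 3 `CCn1c(C(=O)Nc2cccc(C(F)(F)F)c2)ccc1C(CC)(CC)c1ccc(OCCC(O)(CC)CC)c(C)c1` gives 23800 nM

In a functional assay on PC-3 cells (Homo sapiens) for antiproliferative activity, read by MTT assay, with a stated time of 48 h (on this read-out lower numbers stand for stronger inhibition and higher numbers for weaker inhibition), compound 3 gives 23800 nM and compound 2 gives 17800 nM as the two stand level, with a 1.3-fold higher number from compound 2 to compound 3 (0.13 log units; within the scatter) between them. Both stand clear of compound 1, which is left by an 8.3-fold higher number from compound 1 to compound 2 (0.92 log units; beyond the scatter) and by an 11-fold higher number from compound 1 to compound 3 (1.04 log units; beyond the scatter) on the way up.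

Compound 4 `CCn1c(C(=O)N(C)CC(=O)O)ccc1C(CC)(CC)c1ccc(OCCC(O)(CC)CC)c(C)c1` differs from compound 3 in one place: (carboxymethyl)(methyl)amino in place of (3-(trifluoromethyl)phenyl)amino on a carbonyl carbon and nothing else changes. Going by the values given here, no measured step makes this exact exchange. The closest evidence is the step between compound 2 and compound 3, a 1.3-fold higher number from compound 2 to compound 3 (0.13 log units; within the scatter) in size, which exchanges one amide group without a dimethylamino group for another. The two larger steps both start from the 3-(dimethylamino)propyl group of compound 1, and compound 4 does not carry that group. In this assay no step beyond the scatter is therefore expected, although three compounds are a thin basis and the entering group matches none of them. The expected step is a 1.5-fold lower number from compound 3 to compound 4 (0.17 log units; within the scatter) on this reasoning. For compound 4 the estimated value is 16000 nM with 5000 nM to 50000 nM as its expected span.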

Compound 4, half-maximal inhibitory concentration: 2250 nM
Estimate against measurement, compound 4: 7.1-fold (0.85 log units) above; measured number below the stated range.
By their numbers in this assay, from the lowest: compounds 1 and 4 (each within the scatter of the next); then compounds 2 and 3 (each within the scatter of the next).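

At this amide position, a low number in this assay turns out not to depend on the 3-(dimethylamino)propyl group of compound 1: the (carboxymethyl)(methyl)amino group on the carbonyl carbon brings a large change from the aryl amide (an 11-fold lower number from compound 3 to compound 4 (1.02 log units; beyond the scatter)), a modest one from the nitrile (a 7.9-fold lower number from compound 2 to compound 4 (0.90 log units; beyond the scatter)), and a result level with the amine (a 1.0-fold higher number from compound 1 to compound 4 (0.02 log units; within the scatter)). An aliphatic chain alone does not account for this, as compound 2 also carries one on the amide nitrogen yet stays level with compound 3, so among these four compounds the lower numbers go with the end groups amine and carboxylic acid, and the higher ones with nitrile and 3-(trifluoromethyl)phenyl. No measurement shown here explains why an amine and a carboxylic acid end up level.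

Compound 4 differs from the others both in its carboxylic acid and in the methyl on its amide nitrogen, so a comparison with the (carboxymethyl)amino amide would be needed to separate the two. As far as these compounds go, it also remains open whether the number depends on the free acid itself, which the methyl ester or a longer chain such as 3-carboxypropyl could test.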